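The source may hold more compounds than are shown below. What is called first, only, known or untested is meant among the compounds shown, and "the series" means these compounds.

Compound 2 `N#CC1=C(N)Oc2cc3oc(-c4ccccc4)cc(=O)c3c(O)c2C12C(=O)N(Cc1ccccc1)c1ccc(Cl)cc12` belongs to a small set that also holds compound 1 `CN1C(=O)C2(C(C#N)=C(N)Oc3cc4oc(-c5ccccc5)cc(=O)c4c(O)c32)c2cc(Br)ccc21`. In a functional assay on A549 cells (Homo sapiens) for antiproliferative activity, read by MTT assay, with a stated time of 48 h (a higher number here means a weaker inhibitor, a lower number a stronger inhibitor), compound 1 gives 3150 nM. Compound 2 reaches only a limit of this assay, > 50000 nM, and stands at the limit of > 50000 nM in this assay, at which 1 of the 2 values shown sits. Compound 3 `N#CC1=C(N)Oc2cc3oc(-c4ccccc4)cc(=O)c3c(O)c2C12C(=O)N(Cc1ccccc1)c1ccc(Br)cc12` carries the change (bromo in place of chloro on an aromatic carbon), bromo in place of chloro on an aromatic carbon. For the measured compounds named here, no measured pair isolates this swap, so the expectation rests on compound 2 alone. The step that the limit leaves unreadable from compound 2 to compound 3 is expected to stay within the scatter. Compound 3 is therefore estimated at 60000 nM, between 20000 nM and 200000 nM, most likely again reported only as a limit.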

Compound 3, half-maximal inhibitory concentration: > 50000 nM
Compound 3 was reported as a limit; the forecaster's own chance of this, stated with the estimate: 70%; the middle value does not contradict the limit.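

In this assay, the swap of bromo for chloro cannot be read, since compound 2 and compound 3 each stand only at a limit of the assay: the limit of > 50000 nM in this assay, at which 2 of the 3 values shown sit.

With bromo held the same, phenyl in place of hydrogen on a saturated chain carbon bound to an amide-type nitrogen in a ring gives an at least 15-fold higher number from compound 1 to compound 3 (1.20 log units; beyond the scatter). The readable change in activity therefore lies at that chain carbon, while any effect of the halogen stays hidden at the limit.

Still open, from the compounds shown here alone, is how an ethyl group or a longer chain on that nitrogen would read, somewhere short of the phenyl change. Also open, going by these compounds, is whether fluoro on the aromatic carbon would matter once the nitrogen carries a group that keeps values measurable.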